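Swapping a Bromophenyl Ring for Furan on a Shared Core

The compounds below may be only part of what the source reports. "The series", "measured", "known", "first", "only" and "open" are said of these compounds alone.

Of the compounds shown here, three built on one shared core have been measured. Compound 1 `O=C1C(=Cc2ccc(O)cc2)C(=O)N(c2ccc(Cl)cc2)N1c1ccc(Cl)cc1` gives 20600 nM in a functional assay on SMMC-7721 cells (Homo sapiens) for cytotoxicity, read by MTT assay, with a stated time of 72 h; on this read-out lower numbers stand for stronger inhibition and higher numbers for weaker inhibition. Compound 2 `O=C1C(=Cc2ccc(Br)cc2)C(=O)N(c2ccc(Cl)cc2)N1c1ccc(Cl)cc1` gives 16600 nM in this assay, and compound 3 `CC(=C1C(=O)N(c2ccc(Cl)cc2)N(c2ccc(Cl)cc2)C1=O)c1ccc(O)cc1` gives 57000 nM in this assay. Compound 2 holds the lowest of the three numbers, but its gap to compound 1 is within the scatter; only compound 3 stands clearly apart from it.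

Compound 4 `O=C1C(=Cc2ccco2)C(=O)N(c2ccc(Cl)cc2)N1c1ccc(Cl)cc1` has not yet been measured. It differs from compound 2 in one place:

furan-2-yl in place of 4-bromophenyl on a double-bonded chain carbon bound to a double-bonded ring carbon

Two measured steps offer guidance. The step of a 1.2-fold lower number from compound 1 to compound 2 (0.09 log units; within the scatter) shows that changing the group on this aromatic ring barely moved the number. The step of a 2.8-fold higher number from compound 1 to compound 3 (0.44 log units; beyond the scatter) concerns a different site, the chain carbon, and was only modest. Within the data shown here, no measured step replaces the whole ring with a different ring, so the expectation rests on the small effect seen at this position. A change within the scatter, in either direction, is expected in this assay. Compound 4 is therefore estimated at 20000 nM, with a range from 8000 nM to 50000 nM. This estimate corresponds to an expected step of a 1.2-fold higher number from compound 2 to compound 4 (0.08 log units; within the scatter).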

Compound 4, half-maximal inhibitory concentration: 19500 nM
Compound 4: the middle estimate sits 1.0-fold (0.01 log units) above what was measured, and the stated range covers the measured number.
By their numbers in this assay, from the lowest: compounds 2, 4 and 1 (each within the scatter of the next); then compound 3.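

Among these compounds, compound 4 is the first case in which the whole ring at this place, on a double-bonded chain carbon bound to a double-bonded ring carbon, is replaced rather than just a group on it. In this assay the exchange of 4-bromophenyl for furan-2-yl gives a 1.2-fold higher number from compound 2 to compound 4 (0.07 log units; within the scatter) and the exchange of 4-hydroxyphenyl for furan-2-yl gives a 1.1-fold lower number from compound 1 to compound 4 (0.02 log units; within the scatter) and so neither step separates the compounds. A six-membered carbon ring can therefore give way here to a five-membered ring with one hetero atom without moving the number beyond the scatter, although no evidence is available on what lies behind this result.

As far as these compounds go, it remains open whether a non-aromatic group at this place, such as an amine, a carboxylic acid or a longer chain, would leave the number equally unchanged. From the compounds shown here alone, whether a pyridine ring or a cyclohexyl ring would do so is also open.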